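From Compound 2 to Compound 3: a Chloro for Hydrogen

A few compounds are considered here, and "the series" means these few. Any claim that something is new, unique, unknown or untested is made for them only; others in the source may bear on it.

Compound 1 `COc1ccccc1S(=O)(=O)/C=C/c1ccccn1` gives 91% in an ADME assay on microsomes from liver (Homo sapiens) for metabolic stability, read by LC-MS, using NADPH, with stated times of 5 min and 30 min, tested at 1 uM; on this read-out higher numbers stand for a more stable compound and lower numbers for a less stable compound.
Compound 2 `COc1ccccc1S(=O)(=O)/C=C/c1cccnc1` gives 97% in this assay.

Among the compounds with values here, compound 2 holds the higher of the two numbers, but the only measured step, a number 6 percentage points higher from compound 1 to compound 2 (within the scatter), lies within the scatter, so the two compounds cannot be told apart on this read-out. Compound 3 `COc1ccccc1S(=O)(=O)/C=C/c1cccnc1Cl` has not been measured. It differs from compound 2 by chloro in place of hydrogen on an aromatic carbon. Within the data shown here, no measured step bears on this change: the single step in hand concerns the exchange of pyridin-2-yl for pyridin-3-yl and is within the scatter, so nothing here shows how a chloro group shifts the numbers. With compound 2 at 97% near the top of the range, compound 3 is expected to remain high, with a step of a number 4 percentage points lower from compound 2 to compound 3 (within the scatter) not beyond the scatter. Compound 3 is estimated at 93%, between 78% and 100%.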

Compound 3, percent of the compound remaining: 77%
Compound 3: middle estimate off by 16 percentage points, on the high side; measured number below the stated range.
By their numbers in this assay, from the lowest: compound 3; then compounds 1 and 2 (each within the scatter of the next).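

Chloro in place of hydrogen on an aromatic carbon, next to the ring nitrogen and ortho to a large group, gives a number 20 percentage points lower from compound 2 to compound 3 (beyond the scatter) in this assay. The earlier step, a number 6 percentage points higher from compound 1 to compound 2 (within the scatter), did not separate its two compounds, so this position is the only place among those shown where a single change clearly moves the number. The result shows that this read-out is sensitive to a change at this carbon, even though the change enters only one heavy atom. No measurement shown bears on why the number falls with this change.

The compounds shown leave open whether the step belongs to chloro itself or would also follow from another group on this carbon, such as fluoro, methyl or an amine. They also leave open whether chloro would give a similar step on another carbon of the same ring.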